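Compound 3 to compound 4: methylsulfanyl for methoxy

The compounds below may be only part of what the source reports. "The series", "measured", "known", "first", "only" and "open" are said of these compounds alone.

Three compounds with a shared core have numbers in an ADME assay on CCRF-CEM cells (Homo sapiens) for cytotoxicity, with a stated time of 4 days; on this read-out higher numbers stand for lower toxicity in this test and lower numbers for higher toxicity in this test. Compound 1 `Cc1cn([C@@H]2O[C@H](CO[Si](C)(C)C(C)(C)C)[C@@]3(OS(=O)(=O)C=C3N)[C@H]2O[Si](C)(C)C(C)(C)C)c(=O)n(C(=O)c2ccccc2)c1=O` gives 54000 nM, compound 2 `Cc1cn([C@@H]2O[C@H](CO[Si](C)(C)C(C)(C)C)[C@@]3(OS(=O)(=O)C=C3N)[C@H]2O[Si](C)(C)C(C)(C)C)c(=O)n(C(=O)CCCBr)c1=O` gives 11000 nM and compound 3 `COC(=O)CCCC(=O)n1c(=O)c(C)cn([C@@H]2O[C@H](CO[Si](C)(C)C(C)(C)C)[C@@]3(OS(=O)(=O)C=C3N)[C@H]2O[Si](C)(C)C(C)(C)C)c1=O` gives 9900 nM. Compound 3 stands level with compound 2, with a 1.1-fold lower number from compound 2 to compound 3 (0.05 log units; within the scatter). Compound 1 lies apart from both, with a 4.9-fold lower number from compound 1 to compound 2 (0.69 log units; beyond the scatter) and a 5.5-fold lower number from compound 1 to compound 3 (0.74 log units; beyond the scatter).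

Compound 4 `CSC(=O)CCCC(=O)n1c(=O)c(C)cn([C@@H]2O[C@H](CO[Si](C)(C)C(C)(C)C)[C@@]3(OS(=O)(=O)C=C3N)[C@H]2O[Si](C)(C)C(C)(C)C)c1=O` differs from compound 3 in one place: methylsulfanyl in place of methoxy on a carbonyl carbon. In words, this is methylsulfanyl in place of methoxy on a carbonyl carbon.

Going by the values given here, no measured step makes this exchange. The two larger steps replace phenyl on a carbonyl carbon with a chain, a different kind of change, so they say little about it. The nearest evidence is the exchange at the chain end, methoxycarbonyl in place of bromo, which stayed within the scatter at a 1.1-fold lower number from compound 2 to compound 3 (0.05 log units; within the scatter). On that basis, no step beyond the scatter is expected in this assay, and no direction can be supported with any confidence. The expected step is a 1.1-fold lower number from compound 3 to compound 4 (0.04 log units; within the scatter). For compound 4 the estimate is 9000 nM, with an expected range of 4500 nM to 18000 nM.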

Compound 4, half-maximal cytotoxic concentration: 9900 nM
For compound 4 the middle estimate is 1.1-fold (0.04 log units) below the measured one; low and high end bracket the measured number.
By their numbers in this assay, from the lowest: compounds 3, 4 and 2 (each within the scatter of the next); then compound 1.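

In this assay the exchange at the chain end, methylsulfanyl in place of methoxy on a carbonyl carbon, gives no change at the digits printed from compound 3 to compound 4 (within the scatter), and (methylsulfanyl)carbonyl in place of bromo gives a 1.1-fold lower number from compound 2 to compound 4 (0.05 log units; within the scatter), so three different chain ends now stand level and the read-out does not separate them. Compound 1 remains the only compound apart from this group: 3-((methylsulfanyl)carbonyl)propyl in place of phenyl on a carbonyl carbon gives a 5.5-fold lower number from compound 1 to compound 4 (0.74 log units; beyond the scatter), which adds a third chain compound on the same side of that divide, and among the compounds shown the gap follows phenyl against chain rather than the end of the chain. Nothing on hand offers an explanation for the flat result at the chain end.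

Still open, from the compounds shown here alone, is whether this flatness holds for a carboxylic acid, an amide or an amine at the chain end, or for a longer chain carrying the same methylsulfanyl carbonyl end. Also open, going by these compounds, is whether a shorter chain, or a phenyl carrying a substituent, on the same carbonyl carbon would fall with compound 1 or with the chain compounds.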